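Dichlorophenyl Replaces Nitrophenyl on a Pyrazoline Series

The source may report more compounds than this note shows. Statements on the series, on what has been measured and on what is new or still open speak of the compounds shown alone.

The series shares one core and differs only in the aryl group on a saturated carbon of the five-membered ring. Compound 1 `CNC(=O)c1cc(Oc2ccc(C3=NNC(c4cccc(Br)c4)C3)cc2)ccn1` carries a 3-bromophenyl group, and in a functional assay on HepG2 cells (Homo sapiens) for cytotoxicity, read by MTT assay, with a stated time of 72 h (a higher number here means a weaker inhibitor, a lower number a stronger inhibitor), compound 1 gives 1850 nM. Compound 2 `CNC(=O)c1cc(Oc2ccc(C3=NNC(c4cccc([N+](=O)[O-])c4)C3)cc2)ccn1` carries a 3-nitrophenyl group instead, and in this assay compound 2 gives 26500 nM. Among the compounds with values here, compound 2 therefore stands at the highest number of the two measured so far; the single measured step, a 14-fold higher number from compound 1 to compound 2 (1.16 log units; beyond the scatter), is large and beyond the scatter.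

Compound 3 `CNC(=O)c1cc(Oc2ccc(C3=NNC(c4ccc(Cl)c(Cl)c4)C3)cc2)ccn1` has not yet been measured. Its change from compound 2 is 3,4-dichlorophenyl in place of 3-nitrophenyl on a saturated ring carbon. Within the data shown here, the only measured step that bears on this is a 14-fold higher number from compound 1 to compound 2 (1.16 log units; beyond the scatter), which shows a halogen on the phenyl ring standing at a much lower number than the nitro group. Because of a 14-fold higher number from compound 1 to compound 2 (1.16 log units; beyond the scatter) a large step downward in this assay is expected, with an 11-fold lower number from compound 2 to compound 3 (1.03 log units; beyond the scatter), returning toward the region of compound 1. Compound 3 is thus estimated at 2500 nM, within a range of 800 nM to 8000 nM.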

Compound 3, half-maximal inhibitory concentration: 14400 nM
For compound 3 the middle estimate is 5.8-fold (0.76 log units) below the measured one; measured number above the stated range.
By their numbers in this assay, from the lowest: compound 1; then compounds 3 and 2 (each within the scatter of the next).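

In this assay, 3,4-dichlorophenyl in place of 3-nitrophenyl on a saturated ring carbon gives a 1.8-fold lower number from compound 2 to compound 3 (0.26 log units; within the scatter), so the data do not separate these two aryl groups at this position. Replacing the 3-bromophenyl group with 3,4-dichlorophenyl at the same carbon gives a 7.8-fold higher number from compound 1 to compound 3 (0.89 log units; beyond the scatter), which shows that halogen on the phenyl ring does not by itself bring a compound to the number of compound 1; compound 3 goes against the halogen-versus-nitro contrast that the first pair suggested, and among these three compounds only compound 1 stands apart. Nothing available explains why the dichlorinated compound stays so far from the brominated one.

The compounds shown leave open whether the lower number of compound 1 belongs to bromine itself or to the presence of a single halogen on the phenyl ring, a question that a phenyl ring bearing one chlorine would address. They also leave open how this position responds to groups of another kind on the phenyl ring, such as an amine, a methoxy group or a carboxylic acid.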